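The source may hold more compounds than are shown below. What is called first, only, known or untested is meant among the compounds shown, and "the series" means these compounds.

The account follows compound 1, `CCCn1c(=O)[nH]c2nc(-c3ccc(S(=O)(=O)N4CCN(c5ccc(Cl)cc5F)CC4)cc3)[nH]c2c1=O`, in an assay on CHO cells for displacement of a labelled ligand from adenosine receptor A3 (Homo sapiens), read by scintillation counting, with a stated time of 45 min, in the presence of a further agent that is not named here; a higher number here means a weaker inhibitor, a lower number a stronger inhibitor. In this assay compound 1 gives > 1000 nM, which is a limit of the assay and not a number. Compound 2, `CCCn1c(=O)[nH]c2nc(-c3ccc(S(=O)(=O)N4CCN(c5cccc(Cl)c5)CC4)cc3)[nH]c2c1=O`, gives 53.5 nM in this assay. Compound 3, `CCCn1c(=O)[nH]c2nc(-c3ccc(S(=O)(=O)N4CCN(c5ccccc5)C(C)C4)cc3)[nH]c2c1=O`, gives > 1000 nM in this assay, again a limit rather than a number. Compound 1 thus stands at the limit of > 1000 nM in this assay, at which 2 of the 3 values shown sit, so only moves toward lower numbers could be seen from it.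

The unmeasured compound 4 is `CCCn1c(=O)[nH]c2nc(-c3ccc(S(=O)(=O)N4CCN(c5ccccc5)CC4)cc3)[nH]c2c1=O`. It differs from compound 1 in one place: phenyl in place of 4-chloro-2-fluorophenyl on an amine nitrogen in a ring. For the measured compounds named here, the one measured step that bears on this change is an at least 18-fold lower number from compound 1 to compound 2 (1.27 log units; beyond the scatter), where the same 4-chloro-2-fluorophenyl on the amine nitrogen in a ring was also exchanged. Compound 4 carries phenyl rather than the 3-chlorophenyl of compound 2, and compound 3, which bears phenyl together with a further methyl on the ring, sits at the limit. A move toward a lower number is therefore expected, but a more modest one than that step, and with real doubt. Compound 4 is expected to give 300 nM in this assay, within 60 nM to 2000 nM. The expected step is an at least 3.3-fold lower number from compound 1 to compound 4 (0.52 log units; beyond the scatter).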

Compound 4, inhibition constant: > 1000 nM
Compound 4 was reported as a limit; the forecaster's own chance of this, stated with the estimate: 35%; middle value at least 3.3-fold (0.52 log units) away from the limit.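

In this assay, hydrogen in place of chloro on an aromatic carbon gives an at least 18-fold higher number from compound 2 to compound 4 (1.27 log units; beyond the scatter), so the lower number of compound 2 is tied to its 3-chlorophenyl and does not follow from the loss of the 4-chloro-2-fluorophenyl alone. The steps from compound 1 and from compound 3 to compound 4 cannot be read, as both ends of each are limits, so the methyl on the ring of compound 3 cannot be judged either. Among the compounds shown, only compound 2 has left the limit: the limit of > 1000 nM in this assay, at which 3 of the 4 values shown sit.

Going by these compounds, it stays open whether another group in place of that chloro, such as bromo, methyl or methoxy, would keep the number of compound 2. On these data alone, how compound 1, compound 3 and compound 4 rank against one another also stays open.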